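Swapping Pyridin-2-yl for Pyrimidin-2-yl on the Sulfonamide Nitrogen

This account rests on a few compounds, and the source may have more. Where it says the series, first, only, none or still open, it means among the compounds named here.

Of the compounds shown here, two have been measured so far for how strongly they slow the growth of a tumour cell line. Compound 1 `Clc1ccc(C(/C=C/c2ccccc2)=N\Nc2nncc3ccccc23)cc1` gives 0.53 nM in a functional assay on SF-295 cells (Homo sapiens) for antiproliferative activity, read by sulforhodamine B assay, with a stated time of 72 h; on this read-out lower numbers stand for stronger inhibition and higher numbers for weaker inhibition. Compound 2 `O=S(=O)(Nc1ccccn1)c1ccc(Nc2nncc3ccccc23)cc1` gives 8.4 nM in this assay, the higher of the two numbers and so the weaker inhibitor; the gap to compound 1 is wide and lies beyond the usual scatter.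

Compound 3 `O=S(=O)(Nc1ncccn1)c1ccc(Nc2nncc3ccccc23)cc1` has not yet been measured. It differs from compound 2 in one place: pyrimidin-2-yl in place of pyridin-2-yl on a sulfonamide nitrogen. Nothing measured here shows how such a swap plays out, and the two groups match in size and ring type, so only a small step is expected, a 1.2-fold higher number from compound 2 to compound 3 (0.08 log units; within the scatter) in this assay, not beyond the scatter in either direction. Compound 3 is therefore estimated at 10 nM in this assay, within a range from 3 nM to 30 nM.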

Compound 3, half-maximal inhibitory concentration: 7.6 nM
Estimate against measurement, compound 3: 1.3-fold (0.12 log units) above; the range from low to high includes it.
By their numbers in this assay, from the lowest: compound 1; then compounds 3 and 2 (each within the scatter of the next).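

On the sulfonamide nitrogen, pyrimidin-2-yl in place of pyridin-2-yl gives a 1.1-fold lower number from compound 2 to compound 3 (0.04 log units; within the scatter) in this assay. Among the compounds shown here, this is the first comparison here that isolates a single change, and it shows that a ring with 2 hetero atoms and a ring with 1 hetero atom cannot be told apart at this position, for this pair alone. No other measurement is available to explain the result.

As far as these compounds go, it remains open how this position responds to a more different group, such as a plain phenyl ring or a small methyl group. Compound 1 differs from compound 2 and compound 3 in more than one place, so it cannot show what the sulfonamide itself contributes.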